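Cyclobutyl series: chloro-fluoro-phenyl swap carried onto compound 3

The source may hold more compounds than are shown below. What is called first, only, known or untested is meant among the compounds shown, and "the series" means these compounds.

Measured in a functional assay on MCF7 cells (Homo sapiens) for antiproliferative activity, read by CellTiter-Glo, with a stated time of 5 days; on this read-out lower numbers stand for stronger inhibition and higher numbers for weaker inhibition:
- compound 1 `CC/C(=C(/c1ccc(/C=C/C(=O)O)cc1)c1ccc2c(cnn2C)c1)c1ccc(F)cc1Cl` gives 81 nM
- compound 2 `CC/C(=C(/c1ccc(/C=C/C(=O)O)cc1)c1ccc2c(cnn2C)c1)c1ccccc1` gives 300 nM
- compound 3 `O=C(O)/C=C/c1ccc(/C(=C(\c2ccccc2)C2CCC2)c2ccc(-c3cn[nH]c3)cc2)cc1` gives 11 nM

Compound 2 and compound 1 differ in one place: 2-chloro-4-fluorophenyl in place of phenyl on a double-bonded chain carbon bound to a double-bonded chain carbon and a saturated chain carbon. That change gave a 3.7-fold lower number from compound 2 to compound 1 (0.57 log units; beyond the scatter). Compound 3 carries a different core; the difference between the core of compound 3 and the core of compound 2 is not broken down here. In this assay compound 3 stands lowest of the three numbers, beyond the scatter against both compound 1 and compound 2.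

Compound 4 `O=C(O)/C=C/c1ccc(/C(=C(\c2ccc(F)cc2Cl)C2CCC2)c2ccc(-c3cn[nH]c3)cc2)cc1` is not yet measured. Against compound 3 the change is 2-chloro-4-fluorophenyl in place of phenyl on a double-bonded chain carbon bound to a double-bonded chain carbon and a saturated ring carbon. Going by the values given here, this is the same kind of change as the one from compound 2 to compound 1, not the same: the place is described as a double-bonded chain carbon bound to a double-bonded chain carbon and a saturated ring carbon in compound 3, and as one bound to a saturated chain carbon in compound 2. Only one worked example of the change exists, on a different core.

Among the compounds with values here, the expectation for compound 4 is therefore a lower number than compound 3, with a step of about a 2.4-fold lower number from compound 3 to compound 4 (0.39 log units; beyond the scatter), kept smaller than the earlier step because the only precedent is a 3.7-fold lower number from compound 2 to compound 1 (0.57 log units; beyond the scatter) and compound 3 already sits low. The estimate for compound 4 in this assay is 4.5 nM, with a likely range from 1.5 nM to 13 nM.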

Compound 4, half-maximal inhibitory concentration: 2.9 nM
The estimate for compound 4 lay 1.6-fold (0.19 log units) above the measured number; low and high end bracket the measured number.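

In this assay, 2-chloro-4-fluorophenyl in place of phenyl on a double-bonded chain carbon bound to a double-bonded chain carbon and a saturated ring carbon gave a 3.8-fold lower number from compound 3 to compound 4 (0.58 log units; beyond the scatter), so the change lowers the number on the cyclobutyl core as well. Set beside the earlier example, the step carried over from one core to the other with no difference in size that can be told apart from the scatter: the same change on two cores in this assay, a 3.7-fold lower number (0.57 log units; beyond the scatter) from compound 2 to compound 1 and a 3.8-fold lower number (0.58 log units; beyond the scatter) from compound 3 to compound 4, 1.0-fold (0.01 log units) apart, within the scatter of two such steps. This agreement rests on just two pairs of compounds in a single cell assay, so it does not show that the step would hold on any further core in the series, and it gives no account of why the change lowers the number or why the size stayed the same.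

The compounds shown leave open how the step divides between the two halogens, as no phenyl carrying only the chlorine or only the fluorine stands among them. Also open, on these data alone, is whether the step survives on compounds in which a longer chain takes the place of the cyclobutyl group, or an amide takes the place of the carboxylic acid.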